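Swapping 3-methoxyphenyl for 2-bromophenyl on a carbonyl carbon

This account rests on a few compounds, and the source may have more. Where it says the series, first, only, none or still open, it means among the compounds named here.

Compound 1 `COc1cccc(C(=O)n2c(-c3cn(C)c4ccccc34)nc3ccccc32)c1`: 15700 nM
Compound 2 `Cn1cc(-c2nc3ccccc3n2C(=O)c2ccccc2Br)c2ccccc21`: 70100 nM
Compound 3 `COc1cccc(C(=O)n2c(-c3cn(C)c4ccc(OC)cc34)nc3ccccc32)c1`: 14600 nM

In a functional assay on MCF7 cells (Homo sapiens) for inhibition, read by MTT assay, with a stated time of 24 h (on this read-out lower numbers stand for stronger inhibition of growth and higher numbers for weaker inhibition of growth), compound 3 gives 14600 nM, and it cannot be separated from compound 1, the step being a 1.1-fold lower number from compound 1 to compound 3 (0.03 log units; within the scatter). The number for compound 2 is higher than both. Compound 4 `COc1ccc2c(c1)c(-c1nc3ccccc3n1C(=O)c1ccccc1Br)cn2C` has not been measured. It differs from compound 3 by 2-bromophenyl in place of 3-methoxyphenyl on a carbonyl carbon. The same exchange has been measured once, as a 4.5-fold higher number from compound 1 to compound 2 (0.65 log units; beyond the scatter). A similar rise is expected here, since the added methoxy in compound 3 left the number within the scatter of compound 1. The expected step is a 4.2-fold higher number from compound 3 to compound 4 (0.63 log units; beyond the scatter). The estimate for compound 4 is 62000 nM, within an expected range of 27000 nM to 130000 nM.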

Compound 4, concentration for 50% growth inhibition: 55800 nM
The estimate for compound 4 lay 1.1-fold (0.05 log units) above the measured number; measured number inside the range.
By their numbers in this assay, from the lowest: compounds 3 and 1 (each within the scatter of the next); then compounds 4 and 2 (each within the scatter of the next).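

In this assay the rise from 2-bromophenyl in place of 3-methoxyphenyl on a carbonyl carbon recurs as a 3.8-fold higher number from compound 3 to compound 4 (0.58 log units; beyond the scatter) and so no longer rests on a single pair: the same change on two cores in this assay, a 4.5-fold higher number (0.65 log units; beyond the scatter) from compound 1 to compound 2 and a 3.8-fold higher number (0.58 log units; beyond the scatter) from compound 3 to compound 4, 1.2-fold (0.07 log units) apart, within the scatter of two such steps. Methoxy in place of hydrogen on an aromatic carbon also stays within the scatter with 2-bromophenyl on the carbonyl carbon, as a 1.3-fold lower number from compound 2 to compound 4 (0.10 log units; within the scatter) agrees with the earlier pair: the same change on two cores in this assay, a 1.1-fold lower number (0.03 log units; within the scatter) from compound 1 to compound 3 and a 1.3-fold lower number (0.10 log units; within the scatter) from compound 2 to compound 4, 1.2-fold (0.07 log units) apart, within the scatter of two such steps. Going by these compounds, whether the higher number follows the arrival of the bromine or the loss of the methoxy remains open. Also open, on these data alone, is what a plain phenyl, or a phenyl carrying an amine or a carboxylic acid, would give on that carbonyl carbon.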